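Fluoro Added to the Phenylsulfonyl Part of Compound 3

The compounds below may be only part of what the source reports. "The series", "measured", "known", "first", "only" and "open" are said of these compounds alone.

Three compounds share one core. Compound 1 `O=c1cc(CSc2nc3ccccc3c(=O)[nH]2)c2ccc(OS(=O)(=O)c3ccccc3)cc2o1` gives 178000 nM in an ADME assay on Vero cells (Chlorocebus sabaeus) for cytotoxicity, read by polymerase chain reaction, with a stated time of 18 h; on this read-out higher numbers stand for lower toxicity in this test and lower numbers for higher toxicity in this test. Compound 2 `Cc1ccc(S(=O)(=O)Oc2ccc3c(CSc4nc5ccccc5c(=O)[nH]4)cc(=O)oc3c2)cc1` gives 117000 nM in this assay, and compound 3 `Cc1ccc2nc(SCc3cc(=O)oc4cc(OS(=O)(=O)c5ccccc5)ccc34)[nH]c(=O)c2c1` gives 126000 nM in this assay. The number for compound 3 sits within the usual scatter of both compound 1 and compound 2, so the three cannot be told apart on toxicity.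

Compound 4 `Cc1ccc2nc(SCc3cc(=O)oc4cc(OS(=O)(=O)c5ccc(F)cc5)ccc34)[nH]c(=O)c2c1` is not yet measured. It differs from compound 3 by one change: fluoro in place of hydrogen on an aromatic carbon. Within the data shown here, the fluoro sits on the phenyl of the (phenylsulfonyl)oxy group, which none of the measured steps touches. Those steps, a 1.5-fold lower number from compound 1 to compound 2 (0.18 log units; within the scatter) and a 1.4-fold lower number from compound 1 to compound 3 (0.15 log units; within the scatter), each add a methyl at a different place and stay within the scatter. Among the measured compounds shown here, no measured step shows a change of this kind, so the expectation rests on the three numbers being alike. Compound 4 is therefore expected to change by a 1.1-fold lower number from compound 3 to compound 4 (0.06 log units; within the scatter) in this assay, a step inside the scatter. Compound 4 is estimated at 110000 nM, within the range 50000 nM to 250000 nM.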

Compound 4, half-maximal cytotoxic concentration: 86400 nM
Compound 4: middle estimate off by 1.3-fold (0.10 log units), on the high side; the range from low to high includes it.
By their numbers in this assay, from the lowest: compounds 4, 2, 3 and 1 (each within the scatter of the next, the first and the last beyond it).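

Among these compounds, this is the first measured look at the phenyl of the (phenylsulfonyl)oxy group, and in this assay fluoro in place of hydrogen, on an aromatic carbon para to a large group, gives a 1.5-fold lower number from compound 3 to compound 4 (0.16 log units; within the scatter) and so cannot be told from no change at all. This position therefore takes a fluoro without a step beyond the scatter, as the two methyl steps elsewhere on the shared core also stayed inside it. Nothing shown gives a reason for the size of this step.

The compounds shown leave open whether a different group at the same place, such as a methoxy group, an amine or a carboxylic acid, would give a step beyond the scatter. They also leave open whether fluoro on another carbon of this phenyl would read the same in this assay.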